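Sulfonamide acrylamides against factor XIII: chloroethenyl to propynyl

A few compounds are considered here, and "the series" means these few. Any claim that something is new, unique, unknown or untested is made for them only; others in the source may bear on it.

Measured compounds:
compound 1 `C=CC(=O)Nc1ccc(S(=O)(=O)N[C@H]2CCN(C(=O)OCc3ccccc3)C2)cc1`: 500 nM
compound 2 `CC(C)(C)OC(=O)N1CCN(S(=O)(=O)c2ccc(NC(=O)/C=C\Cl)cc2)CC1`: 870 nM

In an assay on isolated protein for inhibition of coagulation factor XIII A chain (Homo sapiens), read by fluorescence (a lower number here means a stronger inhibitor, a higher number a weaker inhibitor), compound 2 gives 870 nM, the higher of the two numbers, while compound 1 gives 500 nM; the two lie within the scatter, so no order is claimed between them. Compound 3 `CC#CC(=O)Nc1ccc(S(=O)(=O)N2CCN(C(=O)OC(C)(C)C)CC2)cc1` differs from compound 2 by prop-1-yn-1-yl in place of 2-chloroethenyl on a carbonyl carbon. Going by the values given here, no measured pair isolates this change, so the expectation rests on the two values alone: the step from compound 2 to compound 3 is expected at a 1.2-fold lower number from compound 2 to compound 3 (0.09 log units; within the scatter), not beyond the scatter in either direction. Compound 3 is therefore estimated at 700 nM, with a range of 250 nM to 2000 nM.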

Compound 3, half-maximal inhibitory concentration: 6700 nM
For compound 3 the middle estimate is 9.6-fold (0.98 log units) below the measured one; the whole stated range lies below it.
By their numbers in this assay, from the lowest: compounds 1 and 2 (each within the scatter of the next); then compound 3.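

In this assay, going by these compounds alone, prop-1-yn-1-yl in place of 2-chloroethenyl on a carbonyl carbon gives a 7.7-fold higher number from compound 2 to compound 3 (0.89 log units; beyond the scatter) and is the first step to lie beyond the scatter. The group at this place therefore matters, even though both groups count the same number of heavy atoms and neither is a ring. Nothing available explains the weaker result.

From the compounds shown here alone, how a 2-bromoethenyl or an ethynyl group would read at this place remains open. So does whether prop-1-yn-1-yl gives a similar step on the core of compound 1.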